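From 2-chlorobenzyl to 3-bromobenzyl on a shared core

The source may hold more compounds than are shown below. What is called first, only, known or untested is meant among the compounds shown, and "the series" means these compounds.

Measured in a functional assay on B16 cells (Mus musculus) for antiproliferative activity, read by MTT assay, with a stated time of 24 h; on this read-out lower numbers stand for stronger inhibition and higher numbers for weaker inhibition:
Compound 1 `COc1cc(OC)c(-c2coc3cc(OCc4ccccc4C(F)(F)F)ccc3c2=O)cc1OC`: 8550 nM
Compound 2 `COc1cc(OC)c(-c2coc3cc(OCc4ccccc4Cl)ccc3c2=O)cc1OC`: 4180 nM

Among the compounds with values here, compound 2 holds the lower of these two numbers, and compound 1 is its only measured neighbour. Compound 3 `COc1cc(OC)c(-c2coc3cc(OCc4cccc(Br)c4)ccc3c2=O)cc1OC` has not yet been measured in this assay. Relative to compound 2 it shows (3-bromophenyl in place of 2-chlorophenyl on a saturated chain carbon bound to an oxygen on an aromatic ring), that is, 3-bromophenyl in place of 2-chlorophenyl on a saturated chain carbon bound to an oxygen on an aromatic ring. Within the data shown here, only one measured step bears on this: a 2.0-fold lower number from compound 1 to compound 2 (0.31 log units; beyond the scatter), with chloro in place of trifluoromethyl on an aromatic carbon. Among the measured compounds shown here, no measured compound carries 3-bromophenyl, so that modest step guides the size of the expectation but not firmly its direction. A small move towards a higher number is expected, estimated as a 1.3-fold higher number from compound 2 to compound 3 (0.12 log units; within the scatter). For compound 3 the estimated value is 5500 nM, with an expected range from 2200 nM to 13000 nM.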

Compound 3, half-maximal inhibitory concentration: 4400 nM
Beside the measured number, compound 3's estimate is 1.3-fold (0.10 log units) above it; measured number inside the range.
By their numbers in this assay, from the lowest: compounds 2, 3 and 1 (each within the scatter of the next, the first and the last beyond it).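

In this assay, exchanging 2-chlorophenyl for 3-bromophenyl on a saturated chain carbon bound to an oxygen on an aromatic ring, which alters both the halogen and its ring number, gives a 1.1-fold higher number from compound 2 to compound 3 (0.02 log units; within the scatter). Set against 2-(trifluoromethyl)phenyl, 3-bromophenyl gives a 1.9-fold lower number from compound 1 to compound 3 (0.29 log units; within the scatter), so the new group cannot be separated from either earlier group, although those two are separated from each other. The position therefore tolerates this double change with no resolved difference from 2-chlorophenyl, and nothing given here accounts for the numbers.

The compounds shown leave open how the halogen and its ring number would each count alone, as 2-bromophenyl and 3-chlorophenyl would show. They also leave open how an amine or a carboxylic acid on this ring, or a longer chain at this oxygen, would read.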